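The source may hold more compounds than are shown below. What is called first, only, known or untested is meant among the compounds shown, and "the series" means these compounds.

In a functional assay on the whole organism with Mus musculus as the target (a higher number here means that more compound is needed for the effect, a lower number that less compound is needed), compound 1 `CN(C)C(=O)/C=C1\CCc2ccc(F)cc21` reaches only a limit, > 100 mg/kg. Within the data shown here, compound 2 `CCNC(=O)/C=C1\CCc2ccc(F)cc21` gives 70 mg/kg, the only true number so far. Compound 3 `CC(C)NC(=O)/C=C1\CCc2ccc(F)cc21` differs from compound 2 by methyl in place of hydrogen on a saturated chain carbon bound to an amide-type nitrogen and a saturated chain carbon, which turns ethylamino into isopropylamino. Among the measured compounds shown here, only one measured step bears on this change: an at least 1.4-fold lower number from compound 1 to compound 2 (0.15 log units; that floor lies within the scatter), with ethylamino in place of dimethylamino. That step is known only as a floor, and the floor lies within the scatter, so it offers no basis for expecting a clear shift in either direction. The expected change is small, within the scatter: a 1.2-fold lower number from compound 2 to compound 3 (0.07 log units; within the scatter). For compound 3 the estimate is 60 mg/kg, with an expected range of 25 mg/kg to 150 mg/kg.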

Compound 3, dose for half-maximal effect: 96 mg/kg
Compound 3: the middle estimate sits 1.6-fold (0.20 log units) below what was measured; measured number inside the range.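

In this assay, methyl in place of hydrogen on a saturated chain carbon bound to an amide-type nitrogen and a saturated chain carbon gives a 1.4-fold higher number from compound 2 to compound 3 (0.14 log units; within the scatter). Ethylamino and isopropylamino therefore cannot be told apart here, so this added methyl produces no clear change. The comparison with the dimethylamino compound gives only an at least 1.0-fold lower number from compound 1 to compound 3 (0.01 log units; that floor lies within the scatter), which cannot be read as a real change. As far as these compounds go, what remains open is whether cyclopropylamino, or a longer chain ending in an amine, in place of ethylamino, would move the number beyond the scatter.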